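Swapping Trifluoromethyl for Methoxy on a Lactam Analogue

The source may hold more compounds than are shown below. What is called first, only, known or untested is meant among the compounds shown, and "the series" means these compounds.

Compound 1 `O=C1C=CCC(/C=C/c2ccc(C(F)(F)F)cc2)O1` and compound 2 `COc1ccc(/C=C/C2CC=CC(=O)O2)cc1` share one core and differ only in the group on the aromatic ring. In a functional assay on NCI/ADR cells (Homo sapiens) for inhibition, read by sulforhodamine B assay, with a stated time of 48 h (a lower number here means a stronger inhibitor of growth, a higher number a weaker inhibitor of growth), compound 1 gives 54.8 uM, while compound 2 gives 17.3 uM; this is a 3.2-fold lower number from compound 1 to compound 2 (0.50 log units; beyond the scatter), made by methoxy in place of trifluoromethyl on an aromatic carbon. Compound 3 `O=C1C=CCC(/C=C/c2ccc(C(F)(F)F)cc2)N1` has a different core; how the two cores differ is not broken down here. In this assay compound 3 gives 71.8 uM, which lies within the scatter of compound 1 and beyond it from compound 2. Compound 4 `COc1ccc(/C=C/C2CC=CC(=O)N2)cc1` is not yet measured and differs from compound 3 by methoxy in place of trifluoromethyl on an aromatic carbon, the same change as before. Because a 3.2-fold lower number from compound 1 to compound 2 (0.50 log units; beyond the scatter) was beyond the scatter on the other core, a similar step is expected here, a 3.0-fold lower number from compound 3 to compound 4 (0.48 log units; beyond the scatter). Compound 4 is therefore estimated at 24 uM, between 10 uM and 60 uM.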

Compound 4, concentration for growth inhibition (reported as GI): 842 uM
For compound 4 the middle estimate is 35-fold (1.55 log units) below the measured one, outside the stated range (above it).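

On the core of compound 3, methoxy in place of trifluoromethyl gives a 12-fold higher number from compound 3 to compound 4 (1.07 log units; beyond the scatter), which runs opposite to the earlier step. In this assay, the change therefore does not carry from one core to the other, even in direction: the same change on two cores in this assay, a 3.2-fold lower number (0.50 log units; beyond the scatter) from compound 1 to compound 2 and a 12-fold higher number (1.07 log units; beyond the scatter) from compound 3 to compound 4, 37-fold (1.57 log units) apart, beyond the scatter of two such steps

This shows that, across these four compounds, the outcome of this swap depends on the core that carries it, but it does not show which feature of the cores is responsible or why. The compounds shown leave open whether a chlorine atom or a nitrile in place of trifluoromethyl would also behave differently on the two cores.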